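A few compounds are considered here, and "the series" means these few. Any claim that something is new, unique, unknown or untested is made for them only; others in the source may bear on it.

Measured so far in an ADME assay on HepG2 cells (Homo sapiens) for cytotoxicity, read by luminescence, CellTiter-Glo and ATP content, with a stated time of 72 h; on this read-out lower numbers stand for an effect already at smaller amounts and higher numbers for an effect only at larger amounts of compound:
- compound 1 `Fc1ccc(Cc2ccc3c(NCCCNCc4ccco4)ccnc3c2)cc1`: 5600 nM
- compound 2 `c1ccc(Cc2ccc3c(NCCCNCc4ccco4)ccnc3c2)cc1`: 16000 nM

Compound 2 holds the higher of the two numbers in this assay; its nearest neighbour is compound 1, and the step of a 2.9-fold higher number from compound 1 to compound 2 (0.46 log units; beyond the scatter) separates them. Within the data shown here, that step, hydrogen in place of fluoro on an aromatic carbon, is the only measured step.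

Compound 3 `COc1ccc(Oc2ccc3c(NCCCNCc4ccco4)ccnc3c2)cc1` is the next compound to be measured. It differs from compound 2 as follows: 4-methoxyphenoxy in place of benzyl on an aromatic carbon. Among the measured compounds shown here, the substituent exchanged here is the whole benzyl group, whereas the one measured step only swapped a fluoro for hydrogen on that group; no measured pair shows what an aryl ether in this position does. For the measured compounds named here, the record therefore gives no precedent of its own for this change, and the one step that exists is modest. Nothing measured argues for a move beyond the scatter in either direction, so compound 3 is expected near compound 2, with the step of a 1.3-fold lower number from compound 2 to compound 3 (0.12 log units; within the scatter) taken as the working estimate and a wide band around it. The estimate for compound 3 is 12000 nM, expected to fall between 4000 nM and 40000 nM.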

Compound 3, half-maximal effective concentration: 5300 nM
The estimate for compound 3 lay 2.3-fold (0.35 log units) above the measured number; low and high end bracket the measured number.
By their numbers in this assay, from the lowest: compounds 3 and 1 (each within the scatter of the next); then compound 2.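

Exchanging the whole group at this position moves the number in this assay by about as much as the earlier fluoro change on the benzyl group, with 4-methoxyphenoxy in place of benzyl giving a modest shift beyond the scatter (a 3.0-fold lower number from compound 2 to compound 3 (0.48 log units; beyond the scatter)). The same 4-methoxyphenoxy group cannot be told apart from 4-fluorobenzyl (a 1.1-fold lower number from compound 1 to compound 3 (0.02 log units; within the scatter)), so the two substituted groups read alike in this assay despite their different make-up. Among these three compounds, the group without a substituent on its outer ring, the benzyl of compound 2, holds the highest number, although only three compounds support that reading and compound 3 also differs from it in the atom joining the outer ring to the core; no supporting measurement is available to account for any of these steps.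

The step to compound 3 combines two changes, so a plain phenoxy group and a 4-methoxybenzyl group would be needed to separate the effect of the ether oxygen from that of the methoxy group. Also open, going by these compounds, is how this position responds to groups of another kind, such as an amine or a carboxylic acid on the outer ring.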